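The source may hold more compounds than are shown below. What is called first, only, known or untested is meant among the compounds shown, and "the series" means these compounds.

Compound 3 `CCOC(=O)C1=C(C)NC(C)=C(C(=O)OC(C)C)C1c1[nH]c(CC)nc1Cl` gives 0.564 nM in an assay on ileum for inhibition of Voltage-dependent L-type calcium channel subunit alpha-1C (Cavia porcellus) (a higher number here means a weaker inhibitor, a lower number a stronger inhibitor), and stands at the low end of the three numbers; compound 1 `CCc1nc(Cl)c(C2C(C(=O)OC(C)C)=C(C)NC(C)=C2C(=O)OC(C)C)[nH]1` gives 0.748 nM, within the scatter of compound 3, while compound 2 `CCc1nc(Cl)c(C2C(C(=O)OC)=C(C)NC(C)=C2C(=O)OCc2ccccc2)[nH]1` gives 1.75 nM, beyond it. Going by the values given here, the one measured step, a 1.3-fold lower number from compound 1 to compound 3 (0.12 log units; within the scatter), shows that a small change at an ester chain barely moves the number. The next compound is compound 4 `CCOC(=O)C1=C(C)NC(C)=C(C(=O)OCc2ccccc2)C1c1[nH]c(CC)nc1Cl`, where the change is benzyl in place of isopropyl on an oxygen next to a carbonyl group. Among the compounds with values here, no measured step covers this swap directly; the only pointer is that compound 2, the single benzyl ester among the three, carries the highest number. A modest upward step is therefore expected, a 2.1-fold higher number from compound 3 to compound 4 (0.33 log units; beyond the scatter). Compound 4 is estimated at 1.2 nM, in a range from 0.5 nM to 3 nM.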

Compound 4, half-maximal inhibitory concentration: 2.66 nM
The estimate for compound 4 lay 2.2-fold (0.35 log units) below the measured number; low and high end bracket the measured number.
By their numbers in this assay, from the lowest: compounds 3 and 1 (each within the scatter of the next); then compounds 2 and 4 (each within the scatter of the next).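

In this assay, going by these compounds alone, benzyl in place of isopropyl on an oxygen next to a carbonyl group is the first change here to clear the scatter, a 4.7-fold higher number from compound 3 to compound 4 (0.67 log units; beyond the scatter). With benzyl in place, the small chain change on the other ester still stays inside it, a 1.5-fold higher number from compound 2 to compound 4 (0.18 log units; within the scatter). That hydrogen-for-methyl change reads alike with isopropyl and with benzyl on the partner ester: the same change on two cores in this assay, a 1.3-fold lower number (0.12 log units; within the scatter) from compound 1 to compound 3 and a 1.5-fold lower number (0.18 log units; within the scatter) from compound 4 to compound 2, 1.1-fold (0.06 log units) apart, within the scatter of two such steps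

From the compounds shown here alone, whether the step depends on the aromatic ring of benzyl or only on a larger group stays open. A cyclohexylmethyl ester or an ester chain ending in an amine would bear on this.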